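Acyl variation on the shared core of the legumain inhibitors

The source may report more compounds than this note shows. Statements on the series, on what has been measured and on what is new or still open speak of the compounds shown alone.

Within the data shown here, compound 2 `C/C=C(\NC(C)=O)C(=O)N1CCC[C@H]1C(=O)NN(CC(N)=O)C(=O)/C=C/C(=O)OCC` holds the lowest number of the two measured so far; in an assay on isolated protein for inhibition of legumain (Mus musculus), read by fluorescence, with stated times of 30 s and 2.5 h (on this read-out lower numbers stand for stronger inhibition and higher numbers for weaker inhibition), compound 2 gives 141 nM. Compound 1 `CCOC(=O)/C=C/C(=O)N(CC(N)=O)NC(=O)[C@@H]1CCCN1C(=O)[C@H]1CCCCN1C(C)=O` gives 638 nM in this assay, and the step of a 4.5-fold lower number from compound 1 to compound 2 (0.66 log units; beyond the scatter) replaced a six-membered ring with an open chain on the carbonyl carbon.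

Compound 3 `CCOC(=O)/C=C/C(=O)N(CC(N)=O)NC(=O)[C@@H]1CCCN1C(=O)C1(NC(C)=O)CC1` differs from compound 2 by a group of 7 heavy atoms (5 carbon, 1 nitrogen, 1 oxygen; one three-membered non-aromatic ring of carbon only) in place of a group of 7 heavy atoms (5 carbon, 1 nitrogen, 1 oxygen; no ring), on a carbonyl carbon. Among the measured compounds shown here, the only step in hand is the ring-to-chain change from compound 1 to compound 2, which gave a modest gain; the present change brings a three-membered ring into the same position, so that step bears on it only loosely and does not settle its direction. A step near the scatter, expected as a 1.8-fold higher number from compound 2 to compound 3 (0.25 log units; within the scatter), seems most plausible, with a wide range.

Compound 3 is estimated at 250 nM in this assay, between 80 nM and 800 nM.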

Compound 3, half-maximal inhibitory concentration: 9.3 nM
The estimate for compound 3 lay 27-fold (1.43 log units) above the measured number, and the stated range ends above it.
By their numbers in this assay, from the lowest: compound 3; then compound 2; then compound 1.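

At the carbonyl carbon whose other neighbours are the amide-type nitrogen in a ring, this assay gives a 15-fold lower number from compound 2 to compound 3 (1.18 log units; beyond the scatter), although the two groups hold the same atoms and differ only in how these are joined, so the arrangement of this acyl group counts, not merely its composition. Against the six-membered ring group, the 1-acetamidocyclopropyl group gives a 69-fold lower number from compound 1 to compound 3 (1.84 log units; beyond the scatter), and since compound 1 also carries a ring yet has the highest number of the three, the presence of a ring alone does not go with the lower numbers here. No measurement on hand accounts for the size of this change.

Still open, going by these compounds, is whether a cyclobutyl or cyclopentyl ring in place of the cyclopropyl ring would hold the number of compound 3. Equally open, on these data alone, is how a free amine in place of the acetamido group would read.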